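Swapping nitro for bromo on the aryl ring

The source may report more compounds than this note shows. Statements on the series, on what has been measured and on what is new or still open speak of the compounds shown alone.

This study follows two compounds that share one core and differ only in the groups attached to it, tested in a functional assay on the whole organism (strain Swiss albino) for inhibition, with Mus musculus as the target, with a stated time of 4 h; a higher number here means that more compound is needed for the effect, a lower number that less compound is needed. Compound 1, with the structure `O=[N+]([O-])c1ccc(-c2csc(Nc3n[nH]c(=S)n3-c3ccccc3)n2)cc1`, gives 300 mg/kg in this assay. Compound 2, with the structure `COc1ccccc1-n1c(Nc2nc(-c3ccc(Cl)cc3)cs2)n[nH]c1=S`, gives 100 mg/kg in this assay. Among these two numbers, compound 1 stands highest, and its gap to compound 2 lies beyond the usual scatter, so more of compound 1 is needed for the same effect.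

The next compound, compound 3, has the structure `S=c1[nH]nc(Nc2nc(-c3ccc(Br)cc3)cs2)n1-c1ccccc1` and has not yet been measured in this assay. Compared with compound 1, the change is bromo in place of nitro on an aromatic carbon. Within the data shown here, no pair of measured compounds shows this exact change on its own, so the only guide is that compound 2 needs a lower dose than compound 1.

Compound 3 is expected to need a somewhat lower dose than compound 1, with a step of a 2.0-fold lower number from compound 1 to compound 3 (0.30 log units; within the scatter) in this assay. The estimated minimum effective dose of compound 3 is 150 mg/kg, with a range from 50 mg/kg to 300 mg/kg.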

Compound 3, minimum effective dose: 300 mg/kg
Compound 3: middle estimate off by 2.0-fold (0.30 log units), on the low side, within the range that was stated.
By their numbers in this assay, from the lowest: compound 2; then compounds 1 and 3 (each within the scatter of the next).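

Among these compounds, with the rest of the molecule held fixed, this assay shows no change at the digits printed from compound 1 to compound 3 (within the scatter) when 4-nitrophenyl becomes 4-bromophenyl, and this gives the first reading of a single change at this position. The nitro group, with its 3 heavy atoms and 2 hydrogen-bond acceptors, gives way to a single bromine with no hydrogen-bond acceptors, yet the dose needed does not shift beyond the usual scatter, so in this pair the two groups cannot be told apart by this measurement. Nothing available here offers an explanation for why these two groups read alike.

On these data alone, what remains open is whether other groups at this same place on the ring would also leave the dose unchanged, for example an amine or a carboxylic acid in place of the bromo. Among the compounds shown here, this is also only one pair in one assay, so it remains open whether the same swap would read the same way in a compound that carries different groups elsewhere on the shared core.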